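Cyclopentyl amide in the shared-core series

A few compounds are considered here, and "the series" means these few. Any claim that something is new, unique, unknown or untested is made for them only; others in the source may bear on it.

Compound 1 `CCC(C)C(NC(=O)n1nnc2ccccc21)C(=O)NC1CCCCC1` carries a different substituent on the shared core than the other two; in a functional assay on MIA PaCa-2 cells (Homo sapiens) for inhibition (a lower number here means a stronger inhibitor, a higher number a weaker inhibitor), compound 1 gives 40200 nM. Compound 2 `CC(C)C(NC(=O)NO)C(=O)NC1CCCCC1` has a shorter side chain; in this assay compound 2 gives only the limit > 100000 nM. Compound 3 `CCC(C)C(NC(=O)NO)C(=O)NC1CCCCC1` is its homologue; in this assay compound 3 likewise gives only the limit > 100000 nM. The step that the two limits leave unreadable from compound 2 to compound 3 is therefore unreadable, both values sitting at the limit of > 100000 nM in this assay, at which 2 of the 3 values shown sit. Compound 3 thus stands at the limit of this assay, with no number of its own.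

Compound 4 `CCC(C)C(NC(=O)NO)C(=O)NC1CCCC1` differs from compound 3 by cyclopentyl in place of cyclohexyl on an amide-type nitrogen. No measured step changes this group, so nothing in the shown data sets a size for the change; compounds 2 and 3 both sit at the limit, and the only numeric value belongs to compound 1 with a different substituent. Compound 4 is expected to remain at or around the limit in this assay, estimated at 150000 nM with a range of 50000 nM to 500000 nM. The step that the limit leaves unreadable from compound 3 to compound 4 is expected to be none beyond the scatter.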

Compound 4, half-maximal inhibitory concentration: > 100000 nM
Compound 4: no number, only a limit (the forecaster's own chance of this, stated with the estimate: 80%); the middle value is on the limit's open side.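

Compound 3 and compound 4 both give only a limit in this assay, so no size can be read for this change: the limit of > 100000 nM in this assay, at which 3 of the 4 values shown sit. Left open is whether cyclopentyl in place of cyclohexyl changes anything on a compound with a measured number, such as compound 1.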